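Dimethylamino for fluoro on the shared core

This account rests on a few compounds, and the source may have more. Where it says the series, first, only, none or still open, it means among the compounds named here.

For the measured compounds named here, compound 1 `O=C1/C(=C\c2ccc(F)cc2)c2ccccc2N1c1c(Cl)cccc1Cl` is the only member of the series with a number so far: in a functional assay on L132 cells (Homo sapiens) for cytotoxicity, read by MTT assay, with a stated time of 72 h (a lower number here means that less compound is needed, a higher number that more compound is needed for the effect), compound 1 gives 13 ug/mL. Compound 2 `Cc1ccc2nc(Cl)c(/C=C3\C(=O)N(c4c(Cl)cccc4Cl)c4ccccc43)cc2c1` was also made on the same core, but in this assay compound 2 is recorded as "not determined" (no result reported), so it offers no comparison. Compound 3 `CN(C)c1ccc(/C=C2\C(=O)N(c3c(Cl)cccc3Cl)c3ccccc32)cc1` keeps the core of compound 1 and differs in one place: dimethylamino in place of fluoro on an aromatic carbon. Going by the values given here, no measured pair in this set shows what such an exchange does in this assay, so any expectation rests on compound 1 alone. The expected step is a 1.2-fold higher number from compound 1 to compound 3 (0.06 log units; within the scatter), within the usual scatter and with no direction favoured, since a small shift either way would not be surprising. For compound 3 the estimate in this assay is 15 ug/mL, with a range from 6 ug/mL to 35 ug/mL.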

Compound 3, concentration for half-maximal effect: > 100 ug/mL
Compound 3: a limit, no number; the forecaster's own chance of this, stated with the estimate: 20%; at least 6.6-fold (0.82 log units) between middle value and limit.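

In this assay, dimethylamino in place of fluoro on an aromatic carbon, para to a large group, gives an at least 7.6-fold higher number from compound 1 to compound 3 (0.88 log units; beyond the scatter), so this position is not indifferent to the group it carries, which compound 1 alone could not show. For compound 3, > 100 ug/mL is a limit of the assay and not a number: the limit of > 100 ug/mL in this assay, at which 1 of the 3 values shown sits.

The step therefore sets only a lower bound on the size of the change, and it rests on a single pair on the shared core.

From the compounds shown here alone, whether this shift belongs to dimethylamino specifically or would follow other replacements of fluoro remains open. A primary amine, a methoxy group or a chlorine atom at the same place would help to separate these readings.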